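A few compounds are considered here, and "the series" means these few. Any claim that something is new, unique, unknown or untested is made for them only; others in the source may bear on it.

Measured so far in a functional assay on HeLa cells (Homo sapiens) for antiproliferative activity, read by MTT assay, with a stated time of 72 h; a lower number here means a stronger inhibitor, a higher number a weaker inhibitor:
Compound 1 `CCCCn1ccnc1-c1cc(OC)c(OC)c(OC)c1`: > 100000 nM, a limit
Compound 2 `CCCCCn1ccnc1-c1cc(OC)c(OC)c(OC)c1`: > 100000 nM, a limit

Compound 2 gives only a limit, > 100000 nM. For the measured compounds named here, the series so far stands at the limit of > 100000 nM in this assay, at which 2 of the 2 values shown sit, so no true number anchors it. Going by the values given here, the only measured step is a step that the two limits leave unreadable from compound 1 to compound 2. It has no readable size and sets no scale for changes on this chain.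

Compound 3 `COc1cc(-c2nccn2-c2ccc(C)cc2)cc(OC)c1OC` brings the next change, 4-methylphenyl in place of pentyl on an aromatic nitrogen, next to the ring atom that bears a large group. Among the compounds with values here, the new substituent carries one six-membered aromatic ring of carbon only, and no measured step covers such a group. The step from the butyl to the pentyl chain therefore bears on this change only weakly.

With compound 2 at the limit of > 100000 nM, any readable result in this assay would be a step toward a stronger inhibitor. The step expected is an at least 2.5-fold lower number from compound 2 to compound 3 (0.39 log units; beyond the scatter), and a further limit remains quite possible. For compound 3 the estimated value is 40000 nM, with an expected range from 5000 nM to 150000 nM.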

Compound 3, half-maximal inhibitory concentration: 700 nM
For compound 3 the middle estimate is 57-fold (1.76 log units) above the measured one; measured number below the stated range.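

In this assay, for the compounds shown here, the aromatic nitrogen of the five-membered ring is the first place where a change yields a readable number: 4-methylphenyl in place of pentyl gives an at least 140-fold lower number from compound 2 to compound 3 (2.15 log units; beyond the scatter) and 4-methylphenyl in place of butyl gives an at least 140-fold lower number from compound 1 to compound 3 (2.15 log units; beyond the scatter) on the same nitrogen. Compound 1 and compound 2 are limits, so each of these steps fixes only a minimum size, and the step between the butyl and pentyl chains cannot be read. With the core unchanged, the swap of an open chain for a six-membered aromatic ring of carbon only is the one difference that separates compound 3 from the two compounds that give no number, and the series otherwise rests on a single limit: the limit of > 100000 nM in this assay, at which 2 of the 3 values shown sit.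

The compounds shown do not separate the contribution of the ring from that of its 4-methyl group, as they include neither unsubstituted phenyl nor a phenyl carrying methoxy or chlorine at that place. They also leave open whether benzyl, with one saturated carbon between the nitrogen and the ring, or a saturated cyclohexyl ring on this nitrogen would keep a readable number.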